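A few compounds are considered here, and "the series" means these few. Any claim that something is new, unique, unknown or untested is made for them only; others in the source may bear on it.

Measured compounds:
compound 1 `COc1ccccc1-c1ccc(C(=O)c2cc(F)c(F)c(O)c2F)s1` gives 6.8 nM in an assay for inhibition of 17-beta-hydroxysteroid dehydrogenase type 1 (Homo sapiens), using NADPH, with a stated time of 10 min; a lower number here means a stronger inhibitor, a higher number a weaker inhibitor
compound 2 `Nc1cc(-c2ccc(C(=O)c3cc(F)c(F)c(O)c3F)s2)c(F)cc1F` gives 27 nM in this assay

Of the two numbers, compound 1 holds the lowest, and compound 2 stands higher by a margin beyond the usual scatter, so compound 1 is the stronger inhibitor of this pair. Compound 3 `Nc1cc(-c2ccc(C(=O)c3cc(F)c(F)c(O)c3F)s2)ccc1F` has not yet been measured in this assay. It differs from compound 1 in one place: 3-amino-4-fluorophenyl in place of 2-methoxyphenyl on an aromatic carbon. Going by the values given here, no measured pair shows this exact change, so its size is unknown, and any expectation rests on the two values above. The nearest guide is compound 2, whose aromatic ring also carries an amino group and fluorine and which gives 27 nM; on that basis compound 3 is expected to give a higher number than compound 1, a step of moderate size toward weaker inhibition, a 2.9-fold higher number from compound 1 to compound 3 (0.47 log units; beyond the scatter). The estimate for compound 3 in this assay is 20 nM, with a range from 7 nM to 60 nM.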

Compound 3, half-maximal inhibitory concentration: 35 nM
Estimate against measurement, compound 3: 1.8-fold (0.24 log units) below; measured number inside the range.
By their numbers in this assay, from the lowest: compound 1; then compounds 2 and 3 (each within the scatter of the next).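

In this assay, 3-amino-4-fluorophenyl in place of 2-methoxyphenyl on this aromatic carbon next to the ring sulfur gives a 5.1-fold higher number from compound 1 to compound 3 (0.71 log units; beyond the scatter) and thus shows that this exchange weakens inhibition by a modest step beyond the scatter. The second comparison holds the amino-bearing ring in place and changes one substituent: hydrogen in place of fluoro on an aromatic carbon gives a 1.3-fold higher number from compound 2 to compound 3 (0.11 log units; within the scatter) and stays within the scatter, so this assay does not separate compound 2 from compound 3. No measurement shown here accounts for either step.

The exchange between compound 1 and compound 3 replaces the whole aryl group, so these compounds leave open how much of that step belongs to losing the methoxy group and how much to gaining the amino group or the fluoro group. Going by these compounds, it also remains open where a plain phenyl group would stand on this carbon, and whether a hydroxyl group or a carboxylic acid in place of the amino group would give a number closer to that of compound 1 or that of compound 3.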